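The source may hold more compounds than are shown below. What is called first, only, known or untested is meant among the compounds shown, and "the series" means these compounds.

Compound 1 `CCCCCCCCCCCCCCCCCC(=O)Nc1nnc(S[C@@H]2O[C@H](COC(C)=O)[C@H](OC(C)=O)[C@H](OC(C)=O)[C@H]2OC(C)=O)s1`: 23600 nM
Compound 2 `CCCCCCCCCCCC(=O)Nc1nnc(S[C@@H]2O[C@H](CO)[C@H](O)[C@H](O)[C@H]2O)s1`: 32000 nM
Compound 3 `CCCCCCCCCCCCCCCC(=O)Nc1nnc(S[C@@H]2O[C@H](COC(C)=O)[C@H](OC(C)=O)[C@H](OC(C)=O)[C@H]2OC(C)=O)s1`: 25400 nM

All three were measured in a functional assay on MDA-MB-231 cells (Homo sapiens) for cytotoxicity, read by MTT assay, with a stated time of 24 h; a higher number here means a weaker inhibitor, a lower number a stronger inhibitor. Compound 2 does not separate from the others: its number and those of compound 1 and compound 3 lie within the usual scatter of one another. Compound 4 `C=CCCCCCCCCC(=O)Nc1nnc(S[C@@H]2O[C@H](CO)[C@H](O)[C@H](O)[C@H]2O)s1` has not yet been measured; it differs from compound 2 by vinyl in place of propyl on a saturated chain carbon, eight bonds along the chain from a carbonyl carbon. Among the compounds with values here, the only measured step that bears on such a change in the saturated chain is a 1.1-fold higher number from compound 1 to compound 3 (0.03 log units; within the scatter), which left the number essentially unmoved. A change in the chain of compound 2 is therefore expected to leave this assay much as it is. The expected step is no change at the digits printed from compound 2 to compound 4 (within the scatter), within the scatter. Compound 4 is estimated at 32000 nM, with a range from 16000 nM to 64000 nM.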

Compound 4, half-maximal inhibitory concentration: 80600 nM
Beside the measured number, compound 4's estimate is 2.5-fold (0.40 log units) below it, outside the stated range (above it).
By their numbers in this assay, from the lowest: compounds 1, 3 and 2 (each within the scatter of the next); then compound 4.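

In this assay, vinyl in place of propyl gives a 2.5-fold higher number from compound 2 to compound 4 (0.40 log units; beyond the scatter) and so moves the number beyond the scatter, if only modestly. This place on the chain is therefore not as silent as the earlier step suggested, where a 1.1-fold higher number from compound 1 to compound 3 (0.03 log units; within the scatter) changed nothing that could be told apart. Nothing shown gives a cause for the new step.

Still open, on these data alone, is whether the double bond or the lost carbon carries this step. As far as these compounds go, what an amine or a carboxylic acid would do at this place is also open.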